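A few compounds are considered here, and "the series" means these few. Any claim that something is new, unique, unknown or untested is made for them only; others in the source may bear on it.

Going by the values given here, compound 2 `COc1ccc(S(=O)(=O)c2cnc3cc(Cl)ccc3c2N2CCC(C)CC2)cc1OC` sits at the low end of the two numbers so far: in an assay on isolated protein for displacement of a labelled ligand from metabotropic glutamate receptor 5 (Homo sapiens), with a stated time of 60 min, tested at 1 uM (on this read-out higher numbers stand for more inhibition at the one concentration tested (going by the name of the read-out) and lower numbers for less inhibition), compound 2 gives 93%, and its nearest neighbour, compound 1 `Cc1ccc(S(=O)(=O)c2cnc3cc(Cl)ccc3c2N2CCC(C)CC2)cc1`, gives 94% in the same assay. Among the compounds with values here, the one step joining them, a number 1 percentage points lower from compound 1 to compound 2 (within the scatter), swapped the aryl ring on the sulfonyl sulfur without any change beyond the scatter.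

Compound 3 `CC1CCN(c2c(S(=O)(=O)c3ccc(Cl)c(Cl)c3)cnc3cc(Cl)ccc23)CC1` continues at the same position: 3,4-dichlorophenyl in place of 3,4-dimethoxyphenyl on a sulfonyl sulfur. Within the data shown here, the only measured step that bears on this change is the one from compound 1 to compound 2, which also replaced the ring on the sulfonyl sulfur and moved the read-out by only a number 1 percentage points lower from compound 1 to compound 2 (within the scatter). On that basis no step beyond the scatter is expected in this assay for the new ring either, and compound 3 is estimated at 90%, with a range from 75% to 98%, meaning an expected step of a number 3 percentage points lower from compound 2 to compound 3 (within the scatter).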

Compound 3, a percentage reported as inhibition, at one concentration (the size of the read-out at that concentration, not a potency): 89%
Compound 3: the middle estimate sits 1 percentage points above what was measured; low and high end bracket the measured number.
By their numbers in this assay, from the lowest: compounds 3, 2 and 1 (each within the scatter of the next).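

The place on the sulfonyl sulfur also accepts a ring carrying chlorine in this assay: the 3,4-dichlorophenyl group gives no change beyond the scatter against 3,4-dimethoxyphenyl (see a number 4 percentage points lower from compound 2 to compound 3 (within the scatter)) or against 4-methylphenyl (see a number 5 percentage points lower from compound 1 to compound 3 (within the scatter)). The two hydrogen-bond acceptors counted on the 3,4-dimethoxyphenyl group can therefore give way to two chlorine atoms without a step beyond the scatter. Across these three compounds, the read-out does not separate the methyl, methoxy and chloro patterns.

From the compounds shown here alone, all three groups are substituted phenyl rings, so the effect of an amine or a carboxylic acid on the ring, or of a longer chain in place of the ring, stays open. Each value is also a reading at one concentration, which leaves any potency differences among the three compounds unresolved.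

No measurement on hand speaks to what lies behind these steps.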